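From fluoro to chloro: estimating compound 4

This account rests on a few compounds, and the source may have more. Where it says the series, first, only, none or still open, it means among the compounds named here.

In a functional assay on MDA-MB-231 cells (Homo sapiens) for antiproliferative activity, read by MTT assay, with a stated time of 48 h (on this read-out lower numbers stand for stronger inhibition and higher numbers for weaker inhibition), compound 1 `O=C(/C=C/c1ccc(O)cc1)Nc1cc2c(Nc3ccc(Cl)c(Cl)c3)ncnc2s1` gives 1980 nM and compound 2 `COc1ccc(/C=C/C(=O)Nc2cc3c(Nc4ccc(Cl)c(Cl)c4)ncnc3s2)cc1` gives 16600 nM. Compound 3 `O=C(/C=C/c1ccccc1)Nc1cc2c(Nc3ccc(F)c(Cl)c3)ncnc2s1` gives 7600 nM, the middle of the three numbers, weaker than compound 1 and stronger than compound 2.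

Compound 4 `O=C(/C=C/c1ccccc1)Nc1cc2c(Nc3ccc(Cl)c(Cl)c3)ncnc2s1` is still unmeasured. It differs from compound 3 by a single swap, chloro in place of fluoro on an aromatic carbon. This turns 3-chloro-4-fluorophenyl into 3,4-dichlorophenyl, the group that compound 1 and compound 2 also carry.

Among the compounds with values here, the only measured step, an 8.4-fold higher number from compound 1 to compound 2 (0.92 log units; beyond the scatter), lies beyond the scatter, but it changes another part of the molecule. Within the data shown here, no measured step tests this halogen swap directly, so compound 3 at 7600 nM serves as the starting point, and no change beyond the scatter is expected. The expected step is small, a 1.3-fold lower number from compound 3 to compound 4 (0.10 log units; within the scatter), and its direction is uncertain. For compound 4 the estimated value is 6000 nM, with an expected range from 2200 nM to 16000 nM.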

Compound 4, half-maximal inhibitory concentration: 4400 nM
The estimate for compound 4 lay 1.4-fold (0.13 log units) above the measured number; the range from low to high includes it.
By their numbers in this assay, from the lowest: compound 1; then compounds 4 and 3 (each within the scatter of the next); then compound 2.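

The first direct test of this halogen swap in this assay gives a 1.7-fold lower number from compound 3 to compound 4 (0.24 log units; within the scatter), so this read-out cannot tell 3-chloro-4-fluorophenyl from 3,4-dichlorophenyl at this position. Compound 4 also gives the 3,4-dichlorophenyl series a reference with neither hydroxy nor methoxy: hydrogen in place of methoxy gives a 3.8-fold lower number from compound 2 to compound 4 (0.58 log units; beyond the scatter), while hydrogen in place of hydroxy gives a 2.2-fold higher number from compound 1 to compound 4 (0.35 log units; beyond the scatter), which places hydrogen between the two oxygen-bearing groups in this assay. Nothing available explains the halogen result or this order of groups.

Still open, going by these compounds, is whether a bromo or methyl group in place of this halogen would also stay within the scatter of these values. Also open, on these data alone, is how an amine or a carboxylic acid would compare with hydroxy, methoxy and hydrogen on the ring that carries them.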